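The source may report more compounds than this note shows. Statements on the series, on what has been measured and on what is new or still open speak of the compounds shown alone.

Measured so far:
compound 1 `CN(C)CCCn1cnnc1-c1cc(Oc2ccc(NC(=O)Nc3ccc(Cl)c(C(F)(F)F)c3)cc2F)ccn1` — in an ADME assay on WI-38 cells (Homo sapiens) for cytotoxicity, read by MTT assay, with a stated time of 72 h (on this read-out higher numbers stand for weaker inhibition and lower numbers for stronger inhibition), compound 1 gives 7910 nM
compound 2 `CN(C)CCCn1cnnc1-c1cc(Oc2ccc(NC(=O)Nc3ccc(F)c(Cl)c3)cc2F)ccn1` — in this assay compound 2 gives 5370 nM

Within the data shown here, compound 2 sits within the scatter of compound 1, the only other number in the set; the two cannot be ranked against each other. Among the measured compounds shown here, the one step measured, a 1.5-fold lower number from compound 1 to compound 2 (0.17 log units; within the scatter), exchanges one substituted phenyl for another on the amide-type nitrogen and moves the number by less than the scatter.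

Compound 3 `CN(C)CCCn1cnnc1-c1cc(Oc2ccc(NC(=O)Nc3ccc(Cl)cc3Cl)cc2F)ccn1` repeats that kind of exchange at the same place: 2,4-dichlorophenyl in place of 3-chloro-4-fluorophenyl on an amide-type nitrogen. For the measured compounds named here, the only step that bears on it is the exchange from compound 1 to compound 2, which did not leave the scatter, so no direction is suggested and no step beyond the scatter is expected in this assay. The estimated step from compound 2 to compound 3 is a 1.0-fold higher number from compound 2 to compound 3 (0.01 log units; within the scatter). Compound 3 is therefore expected at about 5500 nM, with a range from 2500 nM to 12000 nM.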

Compound 3, half-maximal inhibitory concentration: 3260 nM
Beside the measured number, compound 3's estimate is 1.7-fold (0.23 log units) above it; the range from low to high includes it.
By their numbers in this assay, from the lowest: compounds 3, 2 and 1 (each within the scatter of the next, the first and the last beyond it).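

In this assay, the place on the amide-type nitrogen now gives its first step beyond the scatter (a 2.4-fold lower number from compound 1 to compound 3 (0.38 log units; beyond the scatter)), with 2,4-dichlorophenyl in place of 4-chloro-3-(trifluoromethyl)phenyl, though the step is modest. The exchange of 3-chloro-4-fluorophenyl for 2,4-dichlorophenyl stays within the scatter (a 1.6-fold lower number from compound 2 to compound 3 (0.22 log units; within the scatter)), so compound 2 and compound 3 cannot be ranked against each other, and only compound 1 and compound 3 separate at this place. No measurement available here bears on the reason for either step.

From the compounds shown here alone, all three compounds carry a halogen-substituted phenyl at this place, so the reading for an unsubstituted phenyl or a cyclohexyl group remains open. Also open, going by these compounds, is how the number would respond to a morpholine in place of the dimethylamino group on the shared core.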